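Trimming the chain on a nucleoside-like core

The compounds below may be only part of what the source reports. "The series", "measured", "known", "first", "only" and "open" are said of these compounds alone.

Measured so far:
- compound 1, `Nc1nc(O)c2c(n1)n(C1OC(CO)[C@@H](O)[C@H]1O)c(=O)n2C/C=C/c1ccccc1`: 103 uM
- compound 2, `C=CCn1c(=O)n(C2CN(CCCC)CC(CO)O2)c2nc(N)nc(O)c21`: 5 uM
- compound 3, `C=CCn1c(=O)n([C@H]2CO[C@@H](CO)C2)c2nc(N)nc(O)c21`: 83 uM

All three share one core carrying a sugar-like ring on one nitrogen and a short chain on another, and each was tested in a functional assay (B cells) with Mus musculus as the target; a lower number here means that less compound is needed, a higher number that more compound is needed for the effect. Compound 1 gives the highest of the three numbers. Compound 3 gives a number so close to that of compound 1 that the two cannot be told apart; compound 2 sits far lower, beyond the usual scatter, and the comparisons with compound 1 involve changes in more than one place, so nothing about a single group can be drawn from them.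

Compound 4, `CCn1c(=O)n(C2OC(CO)[C@@H](O)[C@H]2O)c2nc(N)nc(O)c21`, is not yet measured. Compared with compound 1 it differs in one place: methyl in place of 2-phenylethenyl on a saturated chain carbon bound to an aromatic nitrogen. Among the measured compounds shown here, no measured pair shows this change, so its size and direction are unknown here; a step of modest size in either direction, or none beyond the scatter, is plausible. The expected step of a 1.2-fold higher number from compound 1 to compound 4 (0.07 log units; within the scatter) is taken as small. Compound 4 is therefore estimated at 120 uM, within a range from 30 uM to 500 uM, since compound 1 at 103 uM is the closest anchor.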

Compound 4, concentration for half-maximal effect: 15 uM
Compound 4: the middle estimate sits 8.0-fold (0.90 log units) above what was measured, and the stated range ends above it.
By their numbers in this assay, from the lowest: compound 2; then compound 4; then compounds 3 and 1 (each within the scatter of the next).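

In this assay, putting methyl in place of 2-phenylethenyl on a saturated chain carbon bound to an aromatic nitrogen gives a 6.9-fold lower number from compound 1 to compound 4 (0.84 log units; beyond the scatter). This is the first single change shown here that moves the number beyond the scatter, so this position does affect the result, and the larger group with its aromatic ring is not needed for the effect. Nothing measured here gives a reason for this step.

The aromatic ring, the double bond and the extra chain length all leave together, so this one step cannot tell which of them matters. As far as these compounds go, a propyl chain, a benzyl group or a chain ending in an amine at this position would begin to separate these parts, and whether the step holds on a different sugar-like ring remains open.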